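This account rests on a few compounds, and the source may have more. Where it says the series, first, only, none or still open, it means among the compounds named here.

Three compounds built on one shared core were tested in a functional assay on DU-145 cells (Homo sapiens) for cytotoxicity, read by sulforhodamine B assay, with a stated time of 48 h; on this read-out lower numbers stand for stronger inhibition and higher numbers for weaker inhibition. Compound 1 `C[C@H]1CC[C@@H]2[C@@H](OC(=O)[C@]23CC(c2ccc(Cl)cc2)=NO3)[C@]2(C)C(=O)C=C[C@@]12O` gives 43000 nM, the second highest of the three numbers. Compound 2 `C[C@H]1CC[C@@H]2[C@@H](OC(=O)[C@]23CC(c2ccc(O)cc2)=NO3)[C@]2(C)C(=O)C=C[C@@]12O` gives 93000 nM, and compound 3 `Cc1ccc(C2=NO[C@]3(C2)C(=O)O[C@@H]2[C@H]3CC[C@H](C)[C@]3(O)C=CC(=O)[C@@]23C)cc1` gives 14000 nM. The steps measured so far are a 2.2-fold higher number from compound 1 to compound 2 (0.34 log units; beyond the scatter) and a 3.1-fold lower number from compound 1 to compound 3 (0.49 log units; beyond the scatter). Compound 4 `C[C@H]1CC[C@@H]2[C@@H](OC(=O)[C@]23CC(c2ccc(F)cc2)=NO3)[C@]2(C)C(=O)C=C[C@@]12O` differs from compound 1 by fluoro in place of chloro on an aromatic carbon. The two measured swaps at this aromatic carbon each moved the number only modestly, and in opposite directions, and neither of them involved fluoro, so no clear pull in either direction is expected here. The expected step is therefore a 1.2-fold higher number from compound 1 to compound 4 (0.07 log units; within the scatter), a change that stays within the usual scatter. Compound 4 is estimated at 50000 nM, with a range from 20000 nM to 130000 nM.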

Compound 4, half-maximal inhibitory concentration: 13000 nM
Estimate against measurement, compound 4: 3.8-fold (0.59 log units) above, and the stated range ends above it.
By their numbers in this assay, from the lowest: compounds 4 and 3 (each within the scatter of the next); then compound 1; then compound 2.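

Replacing chloro with fluoro on this aromatic carbon shifts the number in this assay (a 3.3-fold lower number from compound 1 to compound 4 (0.52 log units; beyond the scatter)), so these two groups are not interchangeable here. Fluoro and methyl cannot be told apart at this position (a 1.1-fold lower number from compound 3 to compound 4 (0.03 log units; within the scatter)), while hydroxy remains the weakest of the four (a 7.2-fold lower number from compound 2 to compound 4 (0.85 log units; beyond the scatter)). Nothing available explains this order.

From the compounds shown here alone, whether an amine, a carboxylic acid or a longer chain at this position would lower the number further remains open. So does whether this order holds in other cells.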